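The source may report more compounds than this note shows. Statements on the series, on what has been measured and on what is new or still open speak of the compounds shown alone.

Working notes on the series at one concentration.

Of the compounds shown here, three have been measured in a functional assay on SK-OV-3 cells (Homo sapiens) for cytotoxicity, read by sulforhodamine B assay, with a stated time of 48 h, tested at 1 uM; on this read-out lower numbers stand for a stronger effect and higher numbers for a weaker effect at the one concentration tested. Compound 1 `COc1ccc(-c2cc(/C=C/C(=O)c3ccc(OC)c(OC)c3)[nH]n2)cc1` gives 112%. Compound 2 `COc1cc(-c2cc(/C=C/C(=O)c3ccc(Cl)c(Cl)c3)[nH]n2)cc(OC)c1OC` gives 89%. Compound 3 `COc1ccc(-c2cc(/C=C/C(=O)c3cc(OC)c(OC)c(OC)c3)[nH]n2)cc1OC` gives 87%. On these three numbers compound 2 stands second highest: its nearest neighbour is compound 3, whose number lies within the usual scatter of it, and its furthest is compound 1, whose higher number lies beyond the scatter. Going by the values given here, no two measured compounds differ in only one place, so no single step between measured compounds can be read off.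

Compound 4 `COc1cc(-c2cc(/C=C/C(=O)c3ccc(F)c(F)c3)[nH]n2)cc(OC)c1OC` has not yet been measured in this assay. Against compound 2 the change is 3,4-difluorophenyl in place of 3,4-dichlorophenyl on a carbonyl carbon. Nothing in the measured set isolates this exchange, so the expectation rests on compound 2 alone. The step expected from compound 2 to compound 4 is a number 4 percentage points higher from compound 2 to compound 4 (within the scatter), small and not beyond the scatter in either direction. Compound 4 is therefore estimated at 93% in this assay, within a range of 75% to 112%.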

Compound 4, a percentage reported as activity, at one concentration (the size of the read-out at that concentration, not a potency): 90%
The estimate for compound 4 lay 3 percentage points above the measured number; the measured number falls inside the stated range.
By their numbers in this assay, from the lowest: compounds 3, 2 and 4 (each within the scatter of the next); then compound 1.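

In this assay, going by these compounds alone, 3,4-difluorophenyl in place of 3,4-dichlorophenyl on a carbonyl carbon gives a number 1 percentage points higher from compound 2 to compound 4 (within the scatter), the first step that can be read at a single place. At this position, with the rest of the structure held constant, the two halogenated phenyl groups cannot be told apart at the one concentration tested. No measurement at hand explains this result.

The compounds shown leave open whether this position responds to anything other than these two groups, for example a phenyl ring carrying an amine or a carboxylic acid. They also leave open whether the same exchange would read the same way on a core with a different methoxy pattern, such as that of compound 1 or compound 3.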